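The source may report more compounds than this note shows. Statements on the series, on what has been measured and on what is new or still open speak of the compounds shown alone.

Compound 1 `O=C(NO)c1ccc(N(Cc2ccc(C3CCCCC3)cc2)C(=O)[C@H]2CCN2S(=O)(=O)c2c(F)c(F)c(F)c(F)c2F)cc1O`: 9700 nM
Compound 2 `O=C(NO)c1ccc(N(Cc2ccc(C3CCCCC3)cn2)C(=O)[C@H]2CCN2S(=O)(=O)c2c(F)c(F)c(F)c(F)c2F)cc1O`: "not determined" (no result reported)
Compound 3 `O=C(NO)c1ccc(N(Cc2cnc(C3CCCCC3)cn2)C(=O)[C@H]2CCN2S(=O)(=O)c2c(F)c(F)c(F)c(F)c2F)cc1O`: "not determined" (no result reported)

In a functional assay on MCF7 cells (Homo sapiens) for antiproliferative activity, with a stated time of 72 h (a higher number here means that more compound is needed for the effect, a lower number that less compound is needed), compound 1 gives 9700 nM. Compound 2 stands without a number in this assay, where it gives "not determined" (no result reported), and compound 3 likewise gives "not determined" (no result reported) in this assay; so neither offers a point of comparison. Compound 4 `O=C([C@H]1CCN1S(=O)(=O)c1c(F)c(F)c(F)c(F)c1F)N(Cc1ccc(C2CCCCC2)cn1)c1ccc2c(=O)[nH]cnc2c1` differs from compound 2 in this way: a group of 11 heavy atoms (8 carbon, 2 nitrogen, 1 oxygen; one six-membered aromatic ring of carbon only, one six-membered aromatic ring with 2 hetero atoms) in place of a group of 11 heavy atoms (7 carbon, 1 nitrogen, 3 oxygen; one six-membered aromatic ring of carbon only), on an amide-type nitrogen. Going by the values given here, no measured step of this kind is available, so the size and direction of the change can only be guessed; the one number known, from compound 1, points to weak activity. The expectation is that compound 4 will also need a large amount of compound. Compound 4 is therefore estimated at 15000 nM in this assay, within a range from 3000 nM to 60000 nM.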

Compound 4, half-maximal effective concentration: 3600 nM
Estimate against measurement, compound 4: 4.2-fold (0.62 log units) above, within the range that was stated.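

Compound 2 offers no single number to set against compound 4, so no step can be read between them. The compounds shown leave open what replacing the 3-hydroxy-4-(hydroxycarbamoyl)phenyl group does to antiproliferative activity. No supporting data bear on this result.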